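The source may report more compounds than this note shows. Statements on the series, on what has been measured and on what is new or still open speak of the compounds shown alone.

Measured so far:
Compound 1, `CCc1ccnc(O[C@@H]2CC[C@@H](C)N(C(=O)c3ccccc3-n3nccn3)C2)c1`: 0.6 nM
Compound 2, `C#Cc1ccnc(O[C@@H]2CC[C@@H](C)N(C(=O)c3ccccc3-n3nccn3)C2)c1`: 0.6 nM

In an assay on CHO-K1 cells for displacement of a labelled ligand from Orexin receptor type 2 (Homo sapiens), read by radioligand binding (on this read-out lower numbers stand for stronger inhibition and higher numbers for weaker inhibition), compound 1 gives 0.6 nM, and in this assay compound 2 gives 0.6 nM. The two numbers agree at the digits shown, so compound 2 stands level with compound 1. For the measured compounds named here, the one measured step, no change at the digits printed from compound 1 to compound 2 (within the scatter), shows no change beyond the scatter when ethynyl replaces ethyl on an aromatic carbon. The next compound, compound 3 `COC(=O)c1ccnc(O[C@@H]2CC[C@@H](C)N(C(=O)c3ccccc3-n3nccn3)C2)c1`, differs from compound 2 by methoxycarbonyl in place of ethynyl on an aromatic carbon. Going by the values given here, no measured step exchanges a group of this kind, so the only guide is that the earlier swap at the same place left the value unmoved; a methoxycarbonyl group, however, brings two hydrogen-bond acceptors where the ethynyl brought none. A modest loss is therefore expected, a 3.3-fold higher number from compound 2 to compound 3 (0.52 log units; beyond the scatter), with wide uncertainty. For compound 3 the expected value is 2 nM, in the range 0.5 nM to 10 nM.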

Compound 3, inhibition constant: 3.9 nM
For compound 3 the middle estimate is 2.0-fold (0.29 log units) below the measured one; the measured number falls inside the stated range.
By their numbers in this assay, from the lowest: compounds 1 and 2 (each within the scatter of the next); then compound 3.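

Methoxycarbonyl in place of ethynyl gives a 6.5-fold higher number from compound 2 to compound 3 (0.81 log units; beyond the scatter) in this assay, and in place of ethyl it gives a 6.5-fold higher number from compound 1 to compound 3 (0.81 log units; beyond the scatter) on the same read-out. The position opposite the ring nitrogen therefore does respond to what sits on it, though the earlier swap between ethyl and ethynyl, with no change beyond the scatter, could not show this. Nothing measured here explains why the number rises with methoxycarbonyl.

From the compounds shown here alone, it remains open whether the rise belongs to the whole methoxycarbonyl group or to one part of it, a question that a carboxylic acid, a primary amide or a methoxymethyl group at this place could help to settle. How a chlorine atom, an amine or a longer chain such as propyl would read here is also unknown.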